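Compound 3 in the Vero cytotoxicity series

The source may hold more compounds than are shown below. What is called first, only, known or untested is meant among the compounds shown, and "the series" means these compounds.

Compound 1 `C=CC(=O)OC1CCC(CN2CCN(c3cc(=O)c4cc(C(F)(F)F)cc([N+](=O)[O-])c4s3)CC2)CC1`: > 64 ug/mL, a limit in an ADME assay on Vero cells (Chlorocebus sabaeus) for cytotoxicity, read by MTT assay, with a stated time of 48 h; on this read-out lower numbers stand for stronger inhibition and higher numbers for weaker inhibition
Compound 2 `COc1ccc(C(=O)OC2CCC(CN3CCN(c4cc(=O)c5cc(C(F)(F)F)cc([N+](=O)[O-])c5s4)CC3)CC2)cc1`: > 64 ug/mL, a limit in this assay

Compound 2 has no number in this assay, only a limit, and it belongs with compound 1 under (the limit of > 64 ug/mL in this assay, at which 2 of the 2 values shown sit). Compound 3 `O=C(OC1CCC(CN2CCN(c3cc(=O)c4cc(C(F)(F)F)cc([N+](=O)[O-])c4s3)CC2)CC1)c1ccc2ccccc2c1` differs from compound 2 by one change: naphthalen-2-yl in place of 4-methoxyphenyl on a carbonyl carbon. For the measured compounds named here, the only measured step at this carbonyl carbon is a step that the two limits leave unreadable from compound 1 to compound 2, so it offers no size to carry over. No readable step and no direction are therefore expected in this assay. This expectation rests on compound 2, whose > 64 ug/mL is a limit. The estimated step is a step that the limit leaves unreadable from compound 2 to compound 3. For compound 3 the expected value is 80 ug/mL, with an estimated range of 40 ug/mL to 160 ug/mL. A further limit rather than a number is the likeliest report for compound 3.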

Compound 3, half-maximal inhibitory concentration: > 64 ug/mL
Compound 3 gave a limit, no number; the forecaster's own chance of this, stated with the estimate: 85%; the middle value is on the limit's open side.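

In this assay compound 3 gives > 64 ug/mL, a limit and not a number. For the compounds shown here, no step among compound 1, compound 2 and compound 3 can be read: the limit of > 64 ug/mL in this assay, at which 3 of the 3 values shown sit. The compounds shown leave open whether any group on this carbonyl carbon gives a measurable value in this assay.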